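Pyridin-4-yl to pyrimidin-5-yl: cytotoxicity working notes

A few compounds are considered here, and "the series" means these few. Any claim that something is new, unique, unknown or untested is made for them only; others in the source may bear on it.

Measured so far:
compound 1, `COc1cccc(S(=O)(=O)/C=C/c2ccncc2)c1`: 21.3%
compound 2, `COc1ccc(S(=O)(=O)/C=C/c2ccncc2)cc1`: 69%
compound 3, `COc1cccc(S(=O)(=O)/C=C/c2cncnc2)c1`: 100%

In an ADME assay on BV-2 cells (Mus musculus) for cytotoxicity, with a stated time of 24 h, tested at 50 uM (on this read-out higher numbers stand for a weaker effect at the one concentration tested and lower numbers for a stronger effect), compound 1 gives 21.3%, the lowest number of the three. Compound 2 shares the same atoms with compound 1 joined differently; the difference between the two cores is not broken down here. Compound 2 gives 69%. The change pyrimidin-5-yl in place of pyridin-4-yl on a double-bonded chain carbon bound to a double-bonded chain carbon on the core of compound 1 leads to compound 3, and compound 3 gives 100%; the step is a number 78.7 percentage points higher from compound 1 to compound 3 (beyond the scatter), which reaches the top of the read-out.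

Compound 4, `COc1ccc(S(=O)(=O)/C=C/c2cncnc2)cc1`, is not yet measured. It carries the same change on the core of compound 2, (pyrimidin-5-yl in place of pyridin-4-yl on a double-bonded chain carbon bound to a double-bonded chain carbon), at a place worded identically. For compound 4 the step is expected to be smaller than the earlier one, a number 28 percentage points higher from compound 2 to compound 4 (beyond the scatter), because compound 2 starts from 69% and the read-out cannot exceed full activity. Compound 4 is therefore expected to give 97%, estimated between 84% and 100%.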

Compound 4, a percentage reported as activity, at one concentration (the size of the read-out at that concentration, not a potency): 100%
For compound 4 the middle estimate is 3 percentage points below the measured one, within the range that was stated.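

In this assay the change pyrimidin-5-yl in place of pyridin-4-yl on a double-bonded chain carbon bound to a double-bonded chain carbon again gives a higher number, a number 31 percentage points higher from compound 2 to compound 4 (beyond the scatter) on the second core, so the direction carries over while the size does not: the same change on two cores in this assay, a number 78.7 percentage points higher (beyond the scatter) from compound 1 to compound 3 and a number 31 percentage points higher (beyond the scatter) from compound 2 to compound 4, 47.7 percentage points apart, beyond the scatter of two such steps

With compound 3 at 100% and compound 4 at 100% the two steps end at the same value at the top of the read-out, from different starting values. This shows that both cores reach that end value with pyrimidin-5-yl, but it does not show how far either step would have run without a top to the read-out, nor that the change would behave the same way on any further core.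

The compounds shown leave open whether an amine or a carboxylic acid in place of pyridin-4-yl would give a number nearer the top or nearer the bottom of the read-out. They also leave open how these compounds compare at any concentration other than the one tested.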